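The source may report more compounds than this note shows. Statements on the series, on what has been measured and on what is new or still open speak of the compounds shown alone.

Compound 1 `CC(C)NC(=N)c1ccc2oc(-c3ccc(OCCCOc4ccccc4)cc3)cc2c1` stands with the highest of the two numbers in an ADME assay on L6 cells (Rattus norvegicus) for cytotoxicity, read by resazurin assay, with a stated time of 70 h (on this read-out lower numbers stand for stronger inhibition and higher numbers for weaker inhibition), where compound 1 gives 45600 nM. Compound 2 `c1ccc(OCCCOc2ccc(-c3cc4cc(C5=NCCN5)ccc4o3)cc2)cc1` in this assay gives 10300 nM; the step of a 4.4-fold lower number from compound 1 to compound 2 (0.65 log units; beyond the scatter) lies on an aromatic carbon of the shared core and leaves the saturated chain untouched. Compound 3 `CC(C)NC(=N)c1ccc2oc(-c3ccc(OCCCCOc4ccccc4)cc3)cc2c1` differs from compound 1 by phenoxymethyl in place of phenoxy on a saturated chain carbon, three bonds along the chain from an oxygen on an aromatic ring. Among the compounds with values here, no measured step alters the saturated chain, so the single step from compound 1 to compound 2 gives no direct guide to this change, and the chain lengthening has no precedent among the measured pairs. In this assay no step beyond the scatter is therefore expected from compound 1 to compound 3, a 1.0-fold lower number from compound 1 to compound 3 (0.01 log units; within the scatter). Compound 3 is expected to give 45000 nM in this assay, with a range from 18000 nM to 110000 nM.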

Compound 3, half-maximal inhibitory concentration: 6900 nM
Compound 3: middle estimate off by 6.5-fold (0.81 log units), on the high side; the measured number lies below the stated range.
By their numbers in this assay, from the lowest: compounds 3 and 2 (each within the scatter of the next); then compound 1.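

In this assay the saturated chain proves a responsive position: phenoxymethyl in place of phenoxy, on a saturated chain carbon, three bonds along the chain from an oxygen on an aromatic ring, gives a 6.6-fold lower number from compound 1 to compound 3 (0.82 log units; beyond the scatter), a step beyond the scatter. Within the data shown here, the earlier compounds showed only a change on an aromatic carbon of the shared core, so this is the first sign that the chain alone, with the rest of compound 1 kept, can move the cytotoxicity read-out. No measurement at hand bears on the origin of this step.

One lengthening cannot show whether 2-phenoxyethyl or 3-phenoxypropyl in the same place would continue the direction of the step. Also open, as far as these compounds go, are the effect of the same lengthening on compound 2 and of an amine on the chain.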